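Notes on the step from compound 1 to compound 3

The source may hold more compounds than are shown below. What is called first, only, known or untested is meant among the compounds shown, and "the series" means these compounds.

Compound 1 `N#Cc1cnc(NCc2cnccc2C(F)(F)F)cc1NC[C@H]1CC[C@@H](O)CC1` is the reference. Among the measured compounds shown here, in an assay on isolated protein for inhibition of protein kinase C theta type (Homo sapiens), read by TR-FRET, with a stated time of 2 h (on this read-out lower numbers stand for stronger inhibition and higher numbers for weaker inhibition), compound 1 gives 58 nM, the lowest of the two numbers so far, though compound 2 `N#Cc1cnc(NCc2cncnc2OCC(F)F)cc1N[C@H]1CC[C@@H](O)CC1` with 90 nM sits within the scatter of it, so no order between the two is claimed. Compound 3 `CC1(C)[C@H](Nc2cc(NCc3cnccc3C(F)(F)F)ncc2C#N)C[C@H]1C(N)=O` is not yet measured. It differs from compound 1 by 3-carbamoyl-2,2-dimethylcyclobutyl in place of (4-hydroxycyclohexyl)methyl on a nitrogen on an aromatic ring. For the measured compounds named here, with no measured pair covering this change, a small step toward weaker inhibition is expected for compound 3, a 1.7-fold higher number from compound 1 to compound 3 (0.24 log units; within the scatter), possibly no larger than the scatter. The expected value for compound 3 is 100 nM, within 30 nM to 400 nM.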

Compound 3, half-maximal inhibitory concentration: 140 nM
Beside the measured number, compound 3's estimate is 1.4-fold (0.15 log units) below it, and the stated range covers the measured number.
By their numbers in this assay, from the lowest: compounds 1, 2 and 3 (each within the scatter of the next, the first and the last beyond it).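

Among the compounds shown here, the first measured change at this position, on a nitrogen on an aromatic ring, gives in this assay a 2.4-fold higher number from compound 1 to compound 3 (0.38 log units; beyond the scatter) and is a modest step toward weaker inhibition. The position therefore accepts 3-carbamoyl-2,2-dimethylcyclobutyl in place of (4-hydroxycyclohexyl)methyl with inhibition still measurable at this level. No available data bear on the reason for this step.

For the compounds shown here, the single step does not separate the contributions of the four-membered ring, the carbamoyl and the two methyl groups. As far as these compounds go, how a carboxylic acid or an amine in place of the carbamoyl would read remains open.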